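The compounds below may be only part of what the source reports. "The series", "measured", "known", "first", "only" and "open" are said of these compounds alone.

Compound 1 `Cc1ccc(C2=Nn3c(Cc4ccc(S(C)(=O)=O)cc4)nnc3SC2)cc1` gives > 100000 nM in a functional assay on RAW264.7 cells (Mus musculus) for cytotoxicity, read by MTT assay, with a stated time of 48 h (a higher number here means a weaker inhibitor, a lower number a stronger inhibitor), which is a limit of the assay and not a number. Compound 2 `CS(=O)(=O)c1ccc(Cc2nnc3n2N=C(c2cc(Cl)sc2S(N)(=O)=O)CS3)cc1` gives > 100000 nM in this assay, again only a limit. Compound 3 `CS(=O)(=O)c1ccc(Cc2nnc3n2N=C(c2cc4ccccc4c(=O)o2)CS3)cc1` gives > 100000 nM in this assay, also a limit.

Compound 2 therefore stands at the limit of this assay, and so do the two other measured compounds; no number separates any of them. For the measured compounds named here, the single one-place step, a step that the two limits leave unreadable from compound 1 to compound 2, cannot be sized because the limit of > 100000 nM in this assay, at which 3 of the 3 values shown sit, is where both of its ends sit. The unmeasured compound 4 `CS(=O)(=O)c1ccc(Cc2nnc3n2N=C(c2ccccc2)CS3)cc1` differs from compound 2 by phenyl in place of 5-chloro-2-sulfamoylthiophen-3-yl on a carbon with a double bond to nitrogen. Going by the values given here, no measured step bears readably on this change, and nothing among the three values hints that compound 4 would leave the limit. The expected step in this assay is a step that the limit leaves unreadable from compound 2 to compound 4, nothing beyond the scatter. Compound 4 is estimated at 150000 nM, within 50000 nM to 500000 nM, and is most likely to be reported only as a limit once more.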

Compound 4, half-maximal inhibitory concentration: 25000 nM
The estimate for compound 4 lay 6.0-fold (0.78 log units) above the measured number, outside the stated range (below it).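

At the carbon with a double bond to nitrogen, an unsubstituted phenyl brings a readable number in this assay, so this position can move the result. Phenyl in place of 5-chloro-2-sulfamoylthiophen-3-yl gives an at least 4.0-fold lower number from compound 2 to compound 4 (0.60 log units; beyond the scatter), and hydrogen in place of methyl on an aromatic carbon gives an at least 4.0-fold lower number from compound 1 to compound 4 (0.60 log units; beyond the scatter), which shows that even the methyl of the 4-methylphenyl group separates a measurable compound from one that is not. Compound 4 alone comes off the shared ceiling: the limit of > 100000 nM in this assay, at which 3 of the 4 values shown sit.

From the compounds shown here alone, both steps start from a limit, so their full size remains open, and the step between compound 1 and compound 2 cannot be read. Going by these compounds, it also remains open whether a fluorine, a methoxy group or an amine on the phenyl ring would keep a readable number or return it to the limit.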